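A few compounds are considered here, and "the series" means these few. Any claim that something is new, unique, unknown or untested is made for them only; others in the source may bear on it.

Compound 1 `O=c1[nH]nc2n(c1=O)CCN2c1ccccc1` and compound 2 `Cc1ccc(N2CCn3c2n[nH]c(=O)c3=O)cc1` share one core and differ only at the aromatic ring attached to it. In an ADME assay on Vero cells (Chlorocebus sabaeus) for cytotoxicity, with a stated time of 72 h, tested at 50 ug/mL (on this read-out lower numbers stand for a weaker effect and higher numbers for a stronger effect at the one concentration tested), compound 1 gives 30%, while compound 2 gives 0%. Among the measured compounds shown here, this sets compound 2 as the lower of the two numbers, with compound 1 as its only neighbour, and the step of a number 30 percentage points lower from compound 1 to compound 2 (beyond the scatter) is the one measured change.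

Compound 3 `O=c1[nH]nc2n(c1=O)CCN2c1ccc(Cl)cc1` follows from compound 2 by a single exchange, (chloro in place of methyl on an aromatic carbon). For the measured compounds named here, no measured step pairs a chloro against a methyl here, so the one step from compound 1 to compound 2 bears only loosely on it: it shows that a change at this aromatic carbon can move the read-out by a modest amount. Compound 3 is therefore expected to stay close to compound 2, with a step of about a number 10 percentage points higher from compound 2 to compound 3 (within the scatter) in this assay. Compound 3 is estimated at 10%, within a range from 0% to 35%.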

Compound 3, a percentage reported as inhibition, at one concentration (the size of the read-out at that concentration, not a potency): 7%
Compound 3: the middle estimate sits 3 percentage points above what was measured; measured number inside the range.
By their numbers in this assay, from the lowest: compounds 2 and 3 (each within the scatter of the next); then compound 1.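

In this assay, chloro in place of methyl on this aromatic carbon gives a number 7 percentage points higher from compound 2 to compound 3 (within the scatter) and so does not separate the two groups. Chloro in place of hydrogen at the same carbon gives a number 23 percentage points lower from compound 1 to compound 3 (beyond the scatter) and, with the earlier methyl step, now gives two different groups at this place, para to a large group, that each stand apart from the hydrogen of compound 1. No evidence is available that explains why either group differs from hydrogen in this read-out.

The compounds shown leave open whether a different kind of group at this carbon, such as an amine, a carboxylic acid or a longer chain, would also stay apart from compound 1. They also leave open whether a chloro or methyl group at any other carbon of the aromatic ring would produce a step of similar size.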